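Thiazole for Pyrimidine on the Piperazine Nitrogen

The compounds below may be only part of what the source reports. "The series", "measured", "known", "first", "only" and "open" are said of these compounds alone.

Measured so far:
compound 1 `COc1ccccc1N1CCN(C(=O)COCc2ccccc2)CC1`: 9200 nM
compound 2 `O=C(COCc1ccccc1)N1CCN(c2ncccn2)CC1`: "not active" (no number reported)

Of the compounds shown here, two have been measured in a functional assay on HEK293 cells for positive allosteric modulation of metabotropic glutamate receptor 5 (Rattus norvegicus), read by fluorescence and calcium flux; a lower number here means that less compound is needed, a higher number that more compound is needed for the effect. Compound 1 `COc1ccccc1N1CCN(C(=O)COCc2ccccc2)CC1` gives 9200 nM, a high concentration, so it is only a weak modulator. Compound 2 `O=C(COCc1ccccc1)N1CCN(c2ncccn2)CC1` is reported in this assay merely as "not active" (no number reported); that is not a number, so compound 2 stands at the very bottom of what has been seen, and the gap to compound 1 cannot be put into a figure.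

The next compound, compound 3 `O=C(COCc1ccccc1)N1CCN(c2nccs2)CC1`, differs from compound 2 in a single place: 1,3-thiazol-2-yl in place of pyrimidin-2-yl on an amine nitrogen in a ring. Going by the values given here, no measured pair shows this change, so nothing here tells how large a step in this assay it brings, or in which direction. Compound 2 offers no number as a starting point, and compound 1 shows that this family reaches only weak activity at best. On that basis compound 3 is expected to stay weak, with an estimated value of about 15000 nM, ranging from 4000 nM to 60000 nM, and a real chance that again no number is reported.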

Compound 3, half-maximal effective concentration: > 10000 nM
Compound 3: a limit, no number; the forecaster's own chance of this, stated with the estimate: 55%; the middle value lies beyond the limit too.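

In this assay compound 3 gives > 10000 nM, which is a limit of the assay and not a number. Putting 1,3-thiazol-2-yl in place of 2-methoxyphenyl on this amine nitrogen in a ring gives an at least 1.0-fold higher number from compound 1 to compound 3 (0.03 log units; that floor lies within the scatter). The true step could be larger, but this floor alone does not show that the swap costs anything, so the five-membered aromatic ring has not brought this family to a clearer reading than the weak one for the 2-methoxyphenyl group. Neither compound 2 nor compound 3 has a number, so the step between them cannot be read, and the only firm boundary here comes from the assay: the limit of > 10000 nM in this assay, at which 1 of the 3 values shown sits.

The compounds shown leave open whether a plain phenyl group, or a phenyl group carrying a chlorine atom in place of the methoxy group, would give a clearly lower number on this nitrogen than the 2-methoxyphenyl group does. They also leave open what happens at the other end of the shared core if the benzyl group is replaced by a longer chain or a basic amine.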